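The source may report more compounds than this note shows. Statements on the series, on what has been measured and on what is new or still open speak of the compounds shown alone.

Of the compounds shown here, three built on one shared core have been tested in a functional assay on MCF7 cells (Homo sapiens) for inhibition, read by MTT assay, with a stated time of 48 h; a lower number here means a stronger inhibitor, a higher number a weaker inhibitor. Compound 1 `COc1cc(N(Cc2nc3ccccc3[nH]2)S(=O)(=O)c2ccccc2)cc(OC)c1OC` gives 27300 nM. Compound 2 `COc1cc(N(Cc2nc3ccccc3[nH]2)S(=O)(=O)c2ccccc2Cl)cc(OC)c1OC` gives 38100 nM, and compound 3 `COc1ccc(S(=O)(=O)N(Cc2nc3ccccc3[nH]2)c2cc(OC)c(OC)c(OC)c2)cc1OC` gives 47700 nM. All three lie within the scatter of one another, so compound 2 cannot be ranked against either; its number simply sits among theirs. Compound 4 `COc1cc(N(Cc2nc3ccccc3[nH]2)C(=O)c2cccc(Cl)c2)cc(OC)c1OC` differs from compound 2 by (3-chlorophenyl)carbonyl in place of (2-chlorophenyl)sulfonyl on a nitrogen on an aromatic ring. Among the measured compounds shown here, no measured step replaces the sulfonyl itself. The nearest comparisons, a 1.4-fold higher number from compound 1 to compound 2 (0.14 log units; within the scatter) and a 1.3-fold higher number from compound 2 to compound 3 (0.10 log units; within the scatter), change only the group on the sulfonyl sulfur or a chloro on an aromatic carbon, and both stay within the scatter. The expected step in this assay is therefore a 1.1-fold lower number from compound 2 to compound 4 (0.04 log units; within the scatter), nothing beyond the scatter. Compound 4 is estimated at 35000 nM, between 12000 nM and 100000 nM.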

Compound 4, half-maximal inhibitory concentration: 34900 nM
Estimate against measurement, compound 4: 1.0-fold (0.00 log units) above, and the stated range covers the measured number.
By their numbers in this assay, from the lowest: compounds 1, 4, 2 and 3 (each within the scatter of the next).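

In this assay, among the compounds shown here, the sulfonyl on the nitrogen is itself replaced for the first time: (3-chlorophenyl)carbonyl in place of (2-chlorophenyl)sulfonyl gives a 1.1-fold lower number from compound 2 to compound 4 (0.04 log units; within the scatter) and in place of phenylsulfonyl gives a 1.3-fold higher number from compound 1 to compound 4 (0.11 log units; within the scatter) so neither step leaves the scatter. Among these compounds, a carbonyl serves this nitrogen as well as a sulfonyl does, although the chloro position changes in the same step. Nothing available explains this result.
Still open, going by these compounds, is whether an amine or a carboxylic acid on the aromatic ring of the carbonyl group, or a longer chain in place of that ring, would move the number beyond the scatter.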